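Methoxy addition on the ester aryl ring

This account rests on a few compounds, and the source may have more. Where it says the series, first, only, none or still open, it means among the compounds named here.

Compound 1 `CCOc1ccc2c(C)cc(=O)oc2c1COC(=O)c1ccc(OC)c(OC)c1` gives 39.2 nM in a functional assay on cells for positive allosteric modulation, with A2780/Taxol (Homo sapiens) as the target, read by MTT assay, with a stated time of 48 h, tested at 10 uM; on this read-out higher numbers stand for weaker inhibition and lower numbers for stronger inhibition. Compound 2 `CCOc1ccc2c(C)cc(=O)oc2c1COC(=O)c1cc(OC)c(OC)c(OC)c1` carries methoxy in place of hydrogen on an aromatic carbon and in this assay compound 2 gives 77.4 nM; the step is a 2.0-fold higher number from compound 1 to compound 2 (0.30 log units; within the scatter). Compound 3 `Cc1cc(=O)oc2c(COC(=O)/C=C/c3ccccc3)c(OC(C)C)ccc12` has another core, and the difference between the two cores is not broken down here. In this assay compound 3 gives 125 nM, which lies within the scatter of compound 2 and beyond it from compound 1. Compound 4 `COc1ccc(/C=C/C(=O)OCc2c(OC(C)C)ccc3c(C)cc(=O)oc23)cc1` differs from compound 3 by methoxy in place of hydrogen on an aromatic carbon. This is the same kind of change as that from compound 1 to compound 2, though the place differs: there the entering group sat ortho to a methoxy group, meta to a large group and meta to a methoxy group; here it sits para to a large group. Because a 2.0-fold higher number from compound 1 to compound 2 (0.30 log units; within the scatter) stayed within the scatter, a step of a 1.4-fold higher number from compound 3 to compound 4 (0.16 log units; within the scatter) is expected. Compound 4 is estimated at 180 nM, between 90 nM and 400 nM.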

Compound 4, half-maximal inhibitory concentration: 8 nM
Estimate against measurement, compound 4: 23-fold (1.35 log units) above; the whole stated range lies above it.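

In this assay, methoxy in place of hydrogen, para to a large group, gives a 16-fold lower number from compound 3 to compound 4 (1.19 log units; beyond the scatter). This change does not carry from one core to the other as a fixed step in this series: the same change on two cores in this assay, a 2.0-fold higher number (0.30 log units; within the scatter) from compound 1 to compound 2 and a 16-fold lower number (1.19 log units; beyond the scatter) from compound 3 to compound 4, 31-fold (1.49 log units) apart, beyond the scatter of two such steps. The two steps differ in both the core and the place where methoxy enters, and each rests on a single pair, so the data do not separate these two factors.

As far as these compounds go, it remains open whether the large step is specific to methoxy or would also appear with a hydroxyl, an ethoxy or an amine at the same place on the phenyl of compound 3. Also open, from the compounds shown here alone, is whether it would persist with a longer chain on the oxygen of the shared core.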